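Swapping an aryl amide for a benzyl amide

This account rests on a few compounds, and the source may have more. Where it says the series, first, only, none or still open, it means among the compounds named here.

Compound 2 `COc1cccc(NC(=O)CSc2nnc(-c3cc(OC)c(OC)c(OC)c3)n2N)c1` is one of two close relatives already tested. In a functional assay on HepG2 cells (Homo sapiens) for antiproliferative activity, read by MTT assay, with a stated time of 48 h (a higher number here means a weaker inhibitor, a lower number a stronger inhibitor), compound 2 gives > 100000 nM, which is a limit of the assay rather than a measured number. Its partner, compound 1 `COc1cc(-c2nnc(SCC(=O)c3ccc(Br)cc3)n2N)cc(OC)c1OC`, gives 92500 nM in this assay. Going by the values given here, the only measured step, an at least 1.0-fold higher number from compound 1 to compound 2 (0.03 log units; that floor lies within the scatter), rests on the limit (the limit of > 100000 nM in this assay, at which 1 of the 2 values shown sits), so it cannot reveal a real difference between the two. Compound 3 `COc1cc(-c2nnc(SCC(=O)NCc3ccc(C)cc3)n2N)cc(OC)c1OC` differs from compound 2 by 4-methylbenzyl in place of 3-methoxyphenyl on an amide-type nitrogen. Among the compounds with values here, no measured step touches this position, so there is nothing to set a direction, and both measured compounds sit within the scatter of each other at very high concentrations. The expected step of a number no higher from compound 2 to compound 3 (the limit leaves the size open) is therefore no change beyond the scatter. Compound 3 is estimated at 100000 nM, with a range from 40000 nM to 250000 nM.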

Compound 3, half-maximal inhibitory concentration: > 100000 nM
Compound 3: a limit, no number; the forecaster's own chance of this, stated with the estimate: 60%; the middle value sits exactly at the limit.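

In this assay compound 3 gives > 100000 nM, which is a limit of the assay and not a number. The step from compound 2 to compound 3 cannot be read, so 4-methylbenzyl in place of 3-methoxyphenyl on the amide-type nitrogen gives no direction, and neither compound has a number to compare. The one step that can be read, an at least 1.0-fold higher number from compound 1 to compound 3 (0.03 log units; that floor lies within the scatter), is only a floor within the scatter, and the values shown now gather at the top of the assay's range: the limit of > 100000 nM in this assay, at which 2 of the 3 values shown sit.

As far as these compounds go, whether any group on this amide-type nitrogen can give a measured value in this assay remains open. From the compounds shown here alone, an amine or a longer chain ending in a carboxylic acid at this position would be a separate test, and how far compound 2 and compound 3 lie past their limits also remains unknown.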